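From furan-2-yl to thiophen-3-yl at the assay limit

The source may report more compounds than this note shows. Statements on the series, on what has been measured and on what is new or still open speak of the compounds shown alone.

Measured so far in a functional assay on HepG2 cells (Homo sapiens) for antiproliferative activity, read by XTT assay, with a stated time of 72 h; on this read-out higher numbers stand for weaker inhibition and lower numbers for stronger inhibition:
- Compound 1 `CNc1ncnc2c1c(-c1cc3ccccc3o1)cn2[C@@H]1O[C@H](CO)[C@@H](O)[C@H]1O`: > 20000 nM (a limit)
- Compound 2 `Nc1nc2c(c(-c3ccco3)cn2[C@@H]2O[C@H](CO)[C@@H](O)[C@H]2O)c(=O)[nH]1`: > 20000 nM (a limit)

Neither compound has a number in this series, only a limit. The two share one mark: the limit of > 20000 nM in this assay, at which 2 of the 2 values shown sit. From the compounds shown here alone, compound 2 therefore stands at that limit, and how far beyond it the true value lies is unknown.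

Compound 3 `Nc1nc2c(c(-c3ccsc3)cn2[C@@H]2O[C@H](CO)[C@@H](O)[C@H]2O)c(=O)[nH]1` differs from compound 2 by thiophen-3-yl in place of furan-2-yl on an aromatic carbon. Within the data shown here, no measured pair shows what such a change does. In this assay no step beyond the usual scatter is therefore expected, and another limit is the likeliest report. The estimated step of a number no higher from compound 2 to compound 3 (the limit leaves the size open) is accordingly small. For compound 3 the estimate is 20000 nM, with an expected range from 6000 nM to 50000 nM.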

Compound 3, half-maximal inhibitory concentration: > 20000 nM
Compound 3: only a limit was reported (the forecaster's own chance of this, stated with the estimate: 80%); the middle value lies on the limit itself.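

Compound 3 is reported only as a limit, > 20000 nM. No step between compound 2 and compound 3 can be read, as both values are limits: the limit of > 20000 nM in this assay, at which 3 of the 3 values shown sit.

The compounds shown leave open how far beyond that limit each true value lies, and whether the three differ at all.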